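Compound 3 to compound 4: acetyl for hydroxymethyl

A few compounds are considered here, and "the series" means these few. Any claim that something is new, unique, unknown or untested is made for them only; others in the source may bear on it.

Measured in a functional assay (trachea) with Cavia porcellus as the target; a higher number here means that more compound is needed for the effect, a lower number that less compound is needed
- compound 1 `C=CCCn1c(=O)c2[nH]cnc2n(CCC)c1=O` gives 200 nM
- compound 2 `CCCn1c(=O)n(CC(=O)O)c(=O)c2[nH]cnc21` gives 41000 nM
- compound 3 `CCCn1c(=O)n(CCO)c(=O)c2[nH]cnc21` gives 510 nM

Compound 3 holds the second highest of the three numbers, with a 2.6-fold higher number from compound 1 to compound 3 (0.41 log units; beyond the scatter) and an 80-fold lower number from compound 2 to compound 3 (1.91 log units; beyond the scatter). Compound 4 `CCCn1c(=O)n(CC(C)=O)c(=O)c2[nH]cnc21` has acetyl in place of hydroxymethyl on a saturated chain carbon bound to an aromatic nitrogen. Only compound 2 carries carboxy, and a 210-fold higher number from compound 1 to compound 2 (2.31 log units; beyond the scatter) is large, as is the step from compound 2 to compound 3. Compound 4 has no carboxy, so the modest step from compound 1 to compound 3 is the closer guide. No step beyond the scatter is expected in this assay, and any shift would more likely be towards a lower number. The estimated step is a 1.3-fold lower number from compound 3 to compound 4 (0.11 log units; within the scatter). For compound 4 the estimate is 400 nM, with an expected range from 120 nM to 1500 nM.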

Compound 4, half-maximal effective concentration: 14900 nM
The estimate for compound 4 lay 37-fold (1.57 log units) below the measured number, outside the stated range (above it).
By their numbers in this assay, from the lowest: compound 1; then compound 3; then compound 4; then compound 2.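

In this assay, replacing the 2-hydroxyethyl chain with 2-oxopropyl gives (a 29-fold higher number from compound 3 to compound 4 (1.47 log units; beyond the scatter)), so a high number at this position does not require carboxy. Compound 4 remains close to the carboxy compound (a 2.8-fold lower number from compound 2 to compound 4 (0.44 log units; beyond the scatter)) and far from the allyl-bearing compound (a 75-fold higher number from compound 1 to compound 4 (1.87 log units; beyond the scatter)). Among these compounds, the two with a carbonyl on this chain, compound 2 and compound 4, have the highest numbers, while compound 1 and compound 3 have none there and stay lower.

As far as these compounds go, whether an amine or a longer chain ending in hydroxy would keep a low number remains open. No evidence here accounts for the shift.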